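The source may report more compounds than this note shows. Statements on the series, on what has been measured and on what is new or still open speak of the compounds shown alone.

Measured so far:
Compound 1 `CCOC(=O)c1cc(N2C(=O)C3=C(CCCC3)C2=O)c(F)cc1Cl`: 87.1 nM
Compound 2 `CCCCOC(=O)c1cc(N2C(=O)C3=C(CCCC3)C2=O)ccc1Cl`: 7760 nM

Both values come from a functional assay on the whole organism with Scenedesmus acutus as the target, with a stated time of 20 h; a lower number here means a stronger inhibitor, a higher number a weaker inhibitor. There, compound 2 stands at 7760 nM, the higher of the two numbers and well beyond the scatter from compound 1, so it is the weaker inhibitor. Compound 3 `CCCCOC(=O)c1cc(N2C(=O)C3=C(CCCC3)C2=O)c(F)cc1Cl` has not yet been measured. It keeps the butoxycarbonyl group of compound 2 and changes in one place: fluoro in place of hydrogen on an aromatic carbon. Going by the values given here, no measured pair shows this change alone. Compound 1 carries the same fluoro group with an ethyl ester and gives 87.1 nM. These two compounds cannot show how much of their gap goes with the fluoro and how much with the ester chain. Even so, a large drop in this assay, beyond the scatter, is expected. The expected change is a 39-fold lower number from compound 2 to compound 3 (1.59 log units; beyond the scatter). For compound 3 the estimate is 200 nM, within an expected range of 50 nM to 800 nM.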

Compound 3, half-maximal inhibitory concentration: 141 nM
For compound 3 the middle estimate is 1.4-fold (0.15 log units) above the measured one; measured number inside the range.
By their numbers in this assay, from the lowest: compounds 1 and 3 (each within the scatter of the next); then compound 2.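

In this assay, the fluoro change can now be read alone: with the butoxycarbonyl group held fixed, fluoro in place of hydrogen on this aromatic carbon, para to that group, gives a 55-fold lower number from compound 2 to compound 3 (1.74 log units; beyond the scatter). With the fluoro group in place, the ethyl ester and the butyl ester cannot be told apart, as ethyl in place of hydrogen on the chain gives a 1.6-fold higher number from compound 1 to compound 3 (0.21 log units; within the scatter). No measurement at hand explains why the fluoro group has so large an effect.

The compounds shown compare only hydrogen and fluoro at this position, so it remains open how a chloro, methoxy or nitrile group would behave there. Also open, going by these compounds, is what a longer chain on the ester, or a carboxylic acid in its place, would do.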